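Cytotoxicity notes: one arm of the chain cut back

This account rests on a few compounds, and the source may have more. Where it says the series, first, only, none or still open, it means among the compounds named here.

In a functional assay on A2780 cells (Homo sapiens) for cytotoxicity (a higher number here means a weaker inhibitor, a lower number a stronger inhibitor), compound 1 `Oc1cc(O)cc(CCCCCCCCC/C=C\CCCCCCCCCc2cc(O)cc(O)c2)c1` gives 10.2 ug/mL and compound 2 `COc1cc(O)cc(CCCCCCC/C=C\CCCCCCCc2cc(O)cc(OC)c2)c1` gives 9.8 ug/mL as its reading, which places compound 1 level with compound 2 within the scatter. Compound 3 `Oc1cc(O)cc(CCCCCCC/C=C\CCCCCCCCCc2cc(O)cc(O)c2)c1` has not yet been measured. It differs from compound 1 by 3,5-dihydroxyphenyl in place of 2-(3,5-dihydroxyphenyl)ethyl on a saturated chain carbon, seven bonds along the chain from a double-bonded chain carbon with the rest of the structure unchanged. Among the compounds with values here, no measured pair isolates this change. Within the data shown here, the only guide is that compound 2 at 9.8 ug/mL lies within the scatter of compound 1 although the two differ in more than one place. The expected step of a 1.0-fold lower number from compound 1 to compound 3 (0.01 log units; within the scatter) in this assay is estimated to stay within the scatter, with no favoured direction. For compound 3 the estimate is 10 ug/mL with an expected range from 5.5 ug/mL to 18 ug/mL for the coming measurement.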

Compound 3, half-maximal inhibitory concentration: 9.4 ug/mL
Beside the measured number, compound 3's estimate is 1.1-fold (0.03 log units) above it; low and high end bracket the measured number.
By their numbers in this assay, from the lowest: compounds 3, 2 and 1 (each within the scatter of the next).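

Cutting back one arm, with 3,5-dihydroxyphenyl in place of 2-(3,5-dihydroxyphenyl)ethyl on a saturated chain carbon, seven bonds along the chain from a double-bonded chain carbon, gives a 1.1-fold lower number from compound 1 to compound 3 (0.04 log units; within the scatter) in this assay and stays within the scatter. Within the data shown here, this is the first comparison that isolates a single place, which compounds 1 and 2 could not do, and it shows that the reading at this position holds with the shorter arm. Nothing on hand accounts for this flat result.

Going by these compounds, whether a longer chain at this position would move the reading beyond the scatter remains open. Also open, on these data alone, is whether an amine or a carboxylic acid in place of the hydroxyl groups on the 3,5-dihydroxyphenyl group would leave it unchanged.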